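From 3,4-dichlorophenyl to 4-methylphenyl

A few compounds are considered here, and "the series" means these few. Any claim that something is new, unique, unknown or untested is made for them only; others in the source may bear on it.

In a functional assay on ID8 cells (Mus musculus) for antiproliferative activity (a lower number here means a stronger inhibitor, a higher number a weaker inhibitor), compound 1 `O=C(Nc1ccc(O)c2c(=O)cc(-c3ccccc3Cl)oc12)c1ccc(Cl)cc1` gives 5500 nM and compound 2 `O=C(Nc1ccc(O)c2c(=O)cc(-c3ccccc3Cl)oc12)c1ccc(Cl)c(Cl)c1` gives 13000 nM, the higher and therefore weaker of the two numbers. Compound 3 `Cc1ccc(C(=O)Nc2ccc(O)c3c(=O)cc(-c4ccccc4Cl)oc23)cc1` carries 4-methylphenyl in place of 3,4-dichlorophenyl on a carbonyl carbon. Within the data shown here, the only measured step that bears on this change is a 2.4-fold higher number from compound 1 to compound 2 (0.37 log units; beyond the scatter), a modest one, with chloro in place of hydrogen on an aromatic carbon. With both chlorines gone, a similarly modest move to a lower number is expected: a 2.0-fold lower number from compound 2 to compound 3 (0.30 log units; within the scatter). The estimate for compound 3 is 6500 nM, within an expected range of 2500 nM to 16000 nM.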

Compound 3, half-maximal inhibitory concentration: 16000 nM
For compound 3 the middle estimate is 2.5-fold (0.39 log units) below the measured one; the measured number falls inside the stated range.
By their numbers in this assay, from the lowest: compound 1; then compounds 2 and 3 (each within the scatter of the next).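

Replacing 3,4-dichlorophenyl with 4-methylphenyl on a carbonyl carbon gives a 1.2-fold higher number from compound 2 to compound 3 (0.09 log units; within the scatter) in this assay and so leaves the two compounds indistinguishable. Methyl in place of chloro on an aromatic carbon gives a 2.9-fold higher number from compound 1 to compound 3 (0.46 log units; beyond the scatter) and shows that this single chloro compares favourably with methyl here, so compound 1 keeps the lowest number of the three. Nothing shown explains these steps. Still open, from the compounds shown here alone, is how a plain phenyl group on the carbonyl carbon would compare. The same holds for a pyridine ring or a cyclohexyl group there.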